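Compound 4: Chloro in Place of Methyl

A few compounds are considered here, and "the series" means these few. Any claim that something is new, unique, unknown or untested is made for them only; others in the source may bear on it.

Compound 1 `CCC(=O)Nc1ccc(C2=NNC(=O)CC2)cc1` gives 0.64 ug/mL
Compound 2 `CCCC(=O)Nc1ccc(C2=NNC(=O)CC2)cc1` gives 1.44 ug/mL
Compound 3 `CC1CC(c2ccc(N)cc2)=NNC1=O` gives 43.8 ug/mL

These numbers come from a functional assay for inhibition, with Homo sapiens as the target (a lower number here means that less compound is needed, a higher number that more compound is needed for the effect), and place compound 2 second highest of the three, with compound 1 lower and compound 3 higher. Compound 4 `O=C1CCC(c2ccc(NC(=O)CCCl)cc2)=NN1` has not yet been measured. It departs from compound 2 by chloro in place of methyl on a saturated chain carbon, two bonds along the chain from a carbonyl carbon. Among the measured compounds shown here, the only measured step at that place is a 2.3-fold higher number from compound 1 to compound 2 (0.35 log units; beyond the scatter) and it is modest. That step puts methyl in place of hydrogen, so it suggests a size but no direction for the change to chloro. An estimated 1.3-fold lower number from compound 2 to compound 4 (0.12 log units; within the scatter) is therefore a small expected move at most. Compound 4 is estimated at 1.1 ug/mL with an expected range from 0.4 ug/mL to 3 ug/mL by this reckoning.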

Compound 4, half-maximal effective concentration: 0.98 ug/mL
For compound 4 the middle estimate is 1.1-fold (0.05 log units) above the measured one; low and high end bracket the measured number.
By their numbers in this assay, from the lowest: compounds 1, 4 and 2 (each within the scatter of the next, the first and the last beyond it); then compound 3.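

In this assay, chloro in place of methyl on this saturated chain carbon, two bonds along the chain from a carbonyl carbon, stays within the scatter (a 1.5-fold lower number from compound 2 to compound 4 (0.17 log units; within the scatter)). Chloro in place of hydrogen at the same carbon also stays within it (a 1.5-fold higher number from compound 1 to compound 4 (0.19 log units; within the scatter)), whereas methyl in place of hydrogen lies beyond it (a 2.3-fold higher number from compound 1 to compound 2 (0.35 log units; beyond the scatter)). Nothing measured here explains these readings. The compounds shown leave open how a fluoro group, an amine or a longer chain would read at this carbon.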